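The source may hold more compounds than are shown below. What is called first, only, known or untested is meant among the compounds shown, and "the series" means these compounds.

Compound 1 `COc1cc(-c2cc(/C=C/C(=O)c3ccc(Cl)c(Cl)c3)[nH]n2)cc(OC)c1OC` and compound 2 `COc1ccc(C(=O)/C=C/c2cc(-c3cc(OC)c(OC)c(OC)c3)n[nH]2)cc1` share a core and differ only in the ring attached to the carbonyl. In a functional assay on TK-10 cells (Homo sapiens) for inhibition, read by sulforhodamine B assay, with a stated time of 48 h (a lower number here means a stronger inhibitor of growth, a higher number a weaker inhibitor of growth), compound 1 gives 43200 nM, while compound 2 gives 5770 nM, the lower of the two numbers; the step of a 7.5-fold lower number from compound 1 to compound 2 (0.87 log units; beyond the scatter) is the only one measured. Compound 3 `COc1cc(-c2cc(/C=C/C(=O)c3ccc(F)c(F)c3)[nH]n2)cc(OC)c1OC` differs from compound 2 by 3,4-difluorophenyl in place of 4-methoxyphenyl on a carbonyl carbon, which runs the measured step back toward a dihalogenated ring, so a higher number is expected, of a size similar to a 7.5-fold lower number from compound 1 to compound 2 (0.87 log units; beyond the scatter). Compound 3 is estimated at 25000 nM, between 8000 nM and 70000 nM, a step of a 4.3-fold higher number from compound 2 to compound 3 (0.64 log units; beyond the scatter).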

Compound 3, concentration for total growth inhibition: 7420 nM
The estimate for compound 3 lay 3.4-fold (0.53 log units) above the measured number; measured number below the stated range.
By their numbers in this assay, from the lowest: compounds 2 and 3 (each within the scatter of the next); then compound 1.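

On the carbonyl carbon, a dihalogenated ring does not by itself go with a weak number: swapping 4-methoxyphenyl for 3,4-difluorophenyl gives a 1.3-fold higher number from compound 2 to compound 3 (0.11 log units; within the scatter) and so no real difference. The choice of halogen does count, since a 5.8-fold lower number from compound 1 to compound 3 (0.77 log units; beyond the scatter) separates the two dihalogenated rings. Nothing available explains why these two halogen pairs differ. Still open, going by these compounds, is whether a phenyl ring bearing an amine or a carboxylic acid would match compound 2 or compound 1. A ring with a single chlorine or a single fluorine also remains to be placed.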